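The compounds below may be only part of what the source reports. "The series", "measured", "known", "first", "only" and "open" are said of these compounds alone.

Measured compounds in an ADME assay on HELF cells (Homo sapiens) for cytotoxicity, with a stated time of 3 days; on this read-out lower numbers stand for higher toxicity in this test and higher numbers for lower toxicity in this test:
- compound 1 `C[C@H](NC(=O)[C@]1(Cc2ccccc2)CCN1C(=O)OCc1ccccc1)C(=O)NCc1ccccc1` gives 100000 nM.
- compound 2 `C[C@H](NC(=O)[C@]1(Cc2ccccc2)CCN1C(=O)OCc1ccccc1)C(=O)NC(C)(C)C` is reported only as a limit, > 100000 nM.
- compound 3 `CC(C)[C@H](NC(=O)[C@]1(Cc2ccccc2)CCN1C(=O)OCc1ccccc1)C(N)=O` is likewise reported only as a limit, > 100000 nM.

Compound 3 thus stands at the upper boundary of what this assay reports, and it shares that position with one further compound, as the limit of > 100000 nM in this assay, at which 2 of the 3 values shown sit, shows. The step from compound 3 to compound 4 `C[C@H](NC(=O)[C@]1(Cc2ccccc2)CCN1C(=O)OCc1ccccc1)C(=O)NC1CCCCC1` replaces (1-(cyclohexylcarbamoyl)ethyl in place of 1-carbamoyl-2-methylpropyl on an amide-type nitrogen). The measured steps that bear on it all concern the same amide-type nitrogen: a number no lower from compound 1 to compound 3 (the limit leaves the size open), a step that the two limits leave unreadable from compound 2 to compound 3, and a number no lower from compound 1 to compound 2 (the limit leaves the size open). Going by the values given here, none of them yields a readable size, and the one numeric value, that of compound 1, sits at the same level as the limits of the others. The measured compounds therefore give no indication that changing the substituent on this amide-type nitrogen moves the read-out in this assay in either direction beyond the scatter. For compound 4 the expectation is accordingly a step of a number no higher from compound 3 to compound 4 (the limit leaves the size open), which amounts to no change beyond the scatter. The estimate for compound 4 in this assay is 100000 nM, with a range from 50000 nM to 100000 nM, and a limit rather than a number is considered likely.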

Compound 4, minimum cytotoxic concentration: > 100000 nM
Compound 4: a limit, no number; the forecaster's own chance of this, stated with the estimate: 60%; the middle value sits exactly at the limit.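

In this assay compound 4 is reported only as a limit, > 100000 nM. With cyclohexyl in place of benzyl on this amide-type nitrogen, the result is a number no lower from compound 1 to compound 4 (the limit leaves the size open). A cyclohexyl group, with its six-membered non-aromatic ring of carbon only, can therefore stand on this amide-type nitrogen without any measurable toxicity appearing in this test, which extends the earlier picture from the benzyl and tert-butyl amides and from the 1-carbamoyl-2-methylpropyl group of compound 3. The steps to compound 4 from compound 1, compound 2 and compound 3 cannot be read for size, so the result adds a further compound at the top of the reported range rather than a measured effect of the change: the limit of > 100000 nM in this assay, at which 3 of the 4 values shown sit.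

The compounds shown leave open how far the values of compound 2, compound 3 and compound 4 lie past the limit, and so whether these groups differ from one another at all. They also leave open whether a group carrying an amine or a carboxylic acid on this amide-type nitrogen would bring the read-out down to a lower number.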